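The compounds below may be only part of what the source reports. "The series", "measured", "known", "first", "only" and "open" are said of these compounds alone.

Measured compounds in an assay on isolated protein for inhibition of protein kinase C zeta type (Homo sapiens), with a stated time of 4 min, tested at 62.5 uM; on this read-out higher numbers stand for more inhibition at the one concentration tested (going by the name of the read-out) and lower numbers for less inhibition:
- compound 1, `CC(C)(C)C1=NN(c2ccccc2F)C(c2ccc(O)cc2)C1`: 57.6%
- compound 2, `CC(C)(C)C1=NN(c2ccc(Cl)cc2)C(c2ccc(F)cc2)C1`: 0%
- compound 3, `CC(C)(C)C1=NN(c2ccc(Cl)cc2)C(c2ccc(Cl)cc2)C1`: 11.8%

Compound 3 stands second highest of the three numbers in this assay. Its nearest neighbour is compound 2, whose number lies lower by the step of a number 11.8 percentage points higher from compound 2 to compound 3 (beyond the scatter); its furthest is compound 1, whose number lies well above it, beyond the scatter. Going by the values given here, compound 1 differs from compound 3 in more than one place, so no single step is drawn between them and only the two values themselves are compared.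

The next compound in the series is compound 4, `CC(C)(C)C1=NN(c2ccc(Cl)cc2)C(c2ccc(Br)cc2)C1`. It differs from compound 3 in one place: bromo in place of chloro on an aromatic carbon. Among the compounds with values here, the one measured step that bears on this change is the halogen exchange from compound 2 to compound 3, a number 11.8 percentage points higher from compound 2 to compound 3 (beyond the scatter), a modest rise beyond the scatter. Within the data shown here, the step now taken is the same kind of change one halogen further along, and only this one precedent exists for it, so the expectation rests on a single step.

For compound 4 a small upward step in this assay is therefore expected, a number 6.2 percentage points higher from compound 3 to compound 4 (within the scatter), with a fair chance that it falls within the scatter. The estimate for compound 4 is 18%, with a range from 5% to 32%.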

Compound 4, a percentage reported as inhibition, at one concentration (the size of the read-out at that concentration, not a potency): 39%
Compound 4: middle estimate off by 21 percentage points, on the low side, and the stated range ends below it.
By their numbers in this assay, from the lowest: compound 2; then compound 3; then compound 4; then compound 1.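

In this assay, going by these compounds alone, the 4-chlorophenyl to 4-bromophenyl change gives a number 27.2 percentage points higher from compound 3 to compound 4 (beyond the scatter) and so adds a second rise at this aromatic carbon, where the earlier compounds offered only one halogen exchange. Taken across the whole set of halogens shown, with the rest of the molecule unchanged, the position gives a number 39 percentage points higher from compound 2 to compound 4 (beyond the scatter) and the three compounds run in the order fluoro, chloro, bromo, with none of the three going against that order, so the choice of halogen here clearly moves the read-out. No measurement in hand accounts for this order.

Three halogens cannot show whether the climb continues with iodo or whether it belongs to halogens at all, since a methyl, a methoxy or an amine on the same carbon could sit anywhere relative to these numbers. Compound 1 differs from this trio in more than one place, so what separates its 57.6% from them remains unassigned between its hydroxy group and its fluorine-bearing ring on nitrogen.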